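Changing the Aryl Group on the Amine of a Shared Core

The source may report more compounds than this note shows. Statements on the series, on what has been measured and on what is new or still open speak of the compounds shown alone.

The three measured compounds and their values in a functional assay on A549 cells (Homo sapiens) for cytotoxicity, read by sulforhodamine B assay; a lower number here means a stronger inhibitor, a higher number a weaker inhibitor:
Compound 1, `C=C1[C@@H](OC(C)=O)C[C@@H]2[C@](C)(CO[Si](C)(C)C(C)(C)C)[C@H](OC(C)=O)CC[C@@]2(C)[C@@H]1C[C@@H](Nc1ccccc1)C1=CCOC1=O`, gives 4500 nM.
Compound 2, `C=C1[C@@H](OC(C)=O)C[C@@H]2[C@](C)(CO[Si](C)(C)C(C)(C)C)[C@H](OC(C)=O)CC[C@@]2(C)[C@@H]1C[C@@H](Nc1ccccc1F)C1=CCOC1=O`, gives 3190 nM.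
Compound 3, `C=C1[C@@H](OC(C)=O)C[C@@H]2[C@](C)(CO[Si](C)(C)C(C)(C)C)[C@H](OC(C)=O)CC[C@@]2(C)[C@@H]1C[C@@H](Nc1ccc(OC)c(OC)c1)C1=CCOC1=O`, gives 4870 nM.

Compound 3 has the highest of the three numbers, but it does not stand apart: the step of a 1.1-fold higher number from compound 1 to compound 3 (0.03 log units; within the scatter) and the step of a 1.5-fold higher number from compound 2 to compound 3 (0.18 log units; within the scatter) both lie within the scatter, so the three compounds cannot be ranked against each other.

Compound 4, `C=C1[C@@H](OC(C)=O)C[C@@H]2[C@](C)(CO[Si](C)(C)C(C)(C)C)[C@H](OC(C)=O)CC[C@@]2(C)[C@@H]1C[C@@H](Nc1ccc(O)cc1)C1=CCOC1=O`, differs from compound 3 by 4-hydroxyphenyl in place of 3,4-dimethoxyphenyl on an amine nitrogen. Two measured steps also swap the aryl group on the amine nitrogen, a 1.1-fold higher number from compound 1 to compound 3 (0.03 log units; within the scatter) and a 1.5-fold higher number from compound 2 to compound 3 (0.18 log units; within the scatter), and a third, a 1.4-fold lower number from compound 1 to compound 2 (0.15 log units; within the scatter), alters that group by a single atom; none of them moves the number beyond the scatter. On this evidence the expected step is a 1.1-fold lower number from compound 3 to compound 4 (0.05 log units; within the scatter), with no change beyond the scatter in either direction. Compound 4 is therefore estimated at 4300 nM in this assay, with a range from 2000 nM to 9500 nM.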

Compound 4, half-maximal inhibitory concentration: 5090 nM
Compound 4: the middle estimate sits 1.2-fold (0.07 log units) below what was measured, and the stated range covers the measured number.
By their numbers in this assay, from the lowest: compounds 2, 1, 3 and 4 (each within the scatter of the next).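

Compound 4 brings the first hydrogen-bond donor to the aryl group on this amine nitrogen, along with fewer heavy atoms than the 3,4-dimethoxyphenyl it replaces, yet in this assay this swap gives a 1.0-fold higher number from compound 3 to compound 4 (0.02 log units; within the scatter) and so no real change. Putting hydroxy in place of hydrogen on the phenyl ring gives a 1.1-fold higher number from compound 1 to compound 4 (0.05 log units; within the scatter) and the swap from 2-fluorophenyl gives a 1.6-fold higher number from compound 2 to compound 4 (0.20 log units; within the scatter) so all four aryl groups shown remain within the scatter of one another. No separate measurement here helps to explain this flat result.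

On these data alone, all four groups on this nitrogen are aromatic rings, so it remains open whether a saturated ring such as cyclohexyl, or a phenyl ring carrying a carboxylic acid, would move the number beyond the scatter. As far as these compounds go, whether changes elsewhere on the shared core would do so also remains open.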